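From a Nitro Group to a Cyclopropyl Urea

The source may hold more compounds than are shown below. What is called first, only, known or untested is meant among the compounds shown, and "the series" means these compounds.

Compound 2 `O=[N+]([O-])c1cc2c(OCCC3CCCCN3)c(-c3ccc4ccccc4c3)c(O)nc2cc1Cl` is one of two measured compounds here. In a functional assay on cells (Pituitary gland cell) for antagonist activity at Gonadotropin-releasing hormone receptor (Rattus norvegicus) (a lower number here means a stronger inhibitor, a higher number a weaker inhibitor), compound 2 gives 53 nM, the higher of the two numbers. Compound 1 `O=C(Nc1cc2c(OCCC3CCCCN3)c(-c3ccc(Cl)c(Cl)c3)c(O)nc2cc1Cl)NC1CC1`, which carries a different aromatic substituent and a urea in place of the nitro group, gives in this assay 18 nM, a lower number beyond the usual scatter. Compound 3 `O=C(Nc1cc2c(OCCC3CCCCN3)c(-c3ccc4ccccc4c3)c(O)nc2cc1Cl)NC1CC1` keeps the rest of compound 2 and makes one change: (cyclopropylcarbamoyl)amino in place of nitro on an aromatic carbon. Within the data shown here, no single-change step between measured compounds is known, so the direction rests on compound 1 alone. Compound 3 is expected at 20 nM, between 6 nM and 65 nM, meaning a step of a 2.7-fold lower number from compound 2 to compound 3 (0.42 log units; beyond the scatter) toward a stronger inhibitor.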

Compound 3, half-maximal inhibitory concentration: 68 nM
For compound 3 the middle estimate is 3.4-fold (0.53 log units) below the measured one; the measured number lies above the stated range.
By their numbers in this assay, from the lowest: compound 1; then compounds 2 and 3 (each within the scatter of the next).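

Swapping nitro for (cyclopropylcarbamoyl)amino on this aromatic carbon, ortho to a chloro group, gives a 1.3-fold higher number from compound 2 to compound 3 (0.11 log units; within the scatter) in this assay, so with naphthalen-2-yl in place, the two groups give numbers that cannot be told apart. With the urea held fixed, naphthalen-2-yl in place of 3,4-dichlorophenyl gives a 3.8-fold higher number from compound 1 to compound 3 (0.58 log units; beyond the scatter), a modest step that the aromatic substituent alone accounts for. Nothing available explains either step. Still open, from the compounds shown here alone, is how an amine or a carboxylic acid would read at this aromatic carbon. Also open, going by these compounds, is whether nitro and the urea would again match alongside 3,4-dichlorophenyl.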